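This account rests on a few compounds, and the source may have more. Where it says the series, first, only, none or still open, it means among the compounds named here.

Compound 1 `Cc1ccc(Nc2ccc3c(c2)C(=O)N(C2CCC(=O)NC2=O)C3=O)cc1` and compound 2 `CCCc1ccc(Nc2ccc3c(c2)C(=O)N(C2CCC(=O)NC2=O)C3=O)cc1` share one core and differ only in the group at the far end of the aryl amine. In an assay on FRT-Jurkat cells for inhibition of nuclear factor NF-kappa-B complex (Homo sapiens), read by flow cytometry, with a stated time of 24 h, tested at 10 uM (a higher number here means more inhibition at the concentration tested (going by the name of the read-out), a lower number less inhibition), compound 1 gives 5%, and compound 2 gives 10%; the step of a number 5 percentage points higher from compound 1 to compound 2 (within the scatter) leaves the two indistinguishable, so compound 2 stands within the scatter of compound 1. Compound 3 `CC(C)c1ccc(Nc2ccc3c(c2)C(=O)N(C2CCC(=O)NC2=O)C3=O)cc1` carries the change (isopropyl in place of propyl on an aromatic carbon). For the measured compounds named here, only that one step bears on this change, and it was within the scatter, so no step beyond the scatter is expected in this assay, with no change at the digits printed from compound 2 to compound 3 (within the scatter) as the expectation. Compound 3 is therefore expected to give 10%, in a range from 0% to 25%.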

Compound 3, a percentage reported as inhibition, at one concentration (the size of the read-out at that concentration, not a potency): 11%
Compound 3: middle estimate off by 1 percentage points, on the low side; the range from low to high includes it.
By their numbers in this assay, from the lowest: compounds 1, 2 and 3 (each within the scatter of the next).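

In this assay, moving from a straight to a branched chain of the same three carbons gives a number 1 percentage points higher from compound 2 to compound 3 (within the scatter) on this aromatic carbon, and replacing methyl with isopropyl gives a number 6 percentage points higher from compound 1 to compound 3 (within the scatter) in the same place. So neither the shape of this chain nor the swap from methyl to isopropyl separates these compounds at the concentration tested. Nothing available gives a reason for these readings.

Still open, on these data alone, is whether an amine, a carboxylic acid or a longer chain at this position would give a reading clear of the scatter.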